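The source may hold more compounds than are shown below. What is called first, only, known or untested is meant among the compounds shown, and "the series" means these compounds.

Compound 1 `CCCn1cc2c(Nc3ccc(OC(F)(F)F)cc3)ncnc2n1`: in an ADME assay on BaF3 cells (Mus musculus) for cytotoxicity (a lower number here means that less compound is needed, a higher number that more compound is needed for the effect), compound 1 gives > 10000 nM, which is a limit of the assay, not a number.
Compound 2 `FC(F)(F)Oc1ccc(Nc2ncnc3c2cnn3C2CCCCC2)cc1`: in this assay compound 2 gives 9300 nM.
Compound 3 `FC(F)(F)Oc1ccc(Nc2ncnc3nn(C4CCCCC4)cc23)cc1`: in this assay compound 3 gives > 10000 nM, again a limit of the assay.

Compound 3 and compound 1 differ by one change, (propyl in place of cyclohexyl on an aromatic nitrogen), and the step that the two limits leave unreadable from compound 3 to compound 1 cannot be read because of the limit of > 10000 nM in this assay, at which 2 of the 3 values shown sit. Compound 2 and compound 3 share the same atoms joined differently; the difference between the two cores is not broken down here. Compound 4 `CCCn1ncc2c(Nc3ccc(OC(F)(F)F)cc3)ncnc21` arises from compound 2 by the same change, (propyl in place of cyclohexyl on an aromatic nitrogen). The step from compound 2 to compound 4 is expected to be a 1.3-fold higher number from compound 2 to compound 4 (0.11 log units; within the scatter), resting on compound 2 giving 9300 nM close to the limit of > 10000 nM in this assay, at which 2 of the 3 values shown sit, and on the unreadable step that the two limits leave unreadable from compound 3 to compound 1. Compound 4 is therefore estimated at 12000 nM, between 5000 nM and 30000 nM.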

Compound 4, half-maximal effective concentration: 6600 nM
Compound 4: the middle estimate sits 1.8-fold (0.26 log units) above what was measured; measured number inside the range.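

In this assay, propyl in place of cyclohexyl on the aromatic nitrogen gives a 1.4-fold lower number from compound 2 to compound 4 (0.15 log units; within the scatter), so on this core the two groups cannot be told apart. The same change on the other core, from compound 3 to compound 1, cannot be read, because both compounds stand at a limit of the assay rather than at a number: the limit of > 10000 nM in this assay, at which 2 of the 4 values shown sit. The two steps therefore cannot be compared, so nothing shown here confirms or rules out that the change behaves alike on both cores.

As far as these compounds go, it remains open whether a different group on that aromatic nitrogen, such as a longer chain, an amine or a carboxylic acid, would shift the number beyond the scatter.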